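A Side-Chain Amine Swap from Compound 1 to Compound 4

This account rests on a few compounds, and the source may have more. Where it says the series, first, only, none or still open, it means among the compounds named here.

Measured so far:
Compound 1 `CCN(CC)CCNc1cc(C)c2cc(NC(=O)c3ccc(Cl)c(Cl)c3)ccc2n1`: 3710 nM
Compound 2 `CCc1ccc(C(=O)Nc2ccc3nc(N4CCN(CC)CC4)cc(C)c3c2)cc1`: 9850 nM
Compound 3 `CCN1CCN(c2cc(C)c3cc(NC(=O)c4ccc(F)c(F)c4)ccc3n2)CC1`: 1980 nM

In a functional assay on SK-BR-3 cells (Homo sapiens) for antiproliferative activity, read by MTT assay, with a stated time of 72 h (a higher number here means a weaker inhibitor, a lower number a stronger inhibitor), compound 1 gives 3710 nM. Compound 2 gives 9850 nM, a higher number than compound 1 and beyond the scatter, while compound 3 gives 1980 nM, a number that lies within the scatter of compound 1. Within the data shown here, the only step between measured compounds differing in one place is a 5.0-fold lower number from compound 2 to compound 3 (0.70 log units; beyond the scatter); it concerns the group on the carbonyl carbon and says nothing about the side-chain amine. Compound 4 `Cc1cc(NCCN2CCCC2)nc2ccc(NC(=O)c3ccc(Cl)c(Cl)c3)cc12` is not yet measured. Its change from compound 1 is pyrrolidin-1-yl in place of diethylamino on a saturated chain carbon, two bonds along the chain from a nitrogen on an aromatic ring. Both groups carry the same heavy-atom count and the same donor and acceptor count, and the amide side of the molecule is untouched. Among the measured compounds shown here, no measured pair tests a change of this kind, so no step beyond the scatter is expected in this assay in either direction. Compound 4 is therefore estimated to give 3200 nM in this assay, between 1200 nM and 9000 nM. The expected step is a 1.2-fold lower number from compound 1 to compound 4 (0.06 log units; within the scatter).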

Compound 4, half-maximal inhibitory concentration: 9530 nM
Estimate against measurement, compound 4: 3.0-fold (0.47 log units) below, outside the stated range (above it).
By their numbers in this assay, from the lowest: compounds 3 and 1 (each within the scatter of the next); then compounds 4 and 2 (each within the scatter of the next).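

In this assay pyrrolidin-1-yl in place of diethylamino gives a 2.6-fold higher number from compound 1 to compound 4 (0.41 log units; beyond the scatter) and so shows that this end of the side chain responds to a change that leaves the heavy-atom, donor and acceptor counts as they were. Among these compounds, this is the first measured step at this place, on a saturated chain carbon, two bonds along the chain from a nitrogen on an aromatic ring, and a five-membered ring in place of an open amine is enough there to move the number beyond the scatter. Nothing at hand accounts for this step.

From the compounds shown here alone, it remains open whether piperidin-1-yl, morpholin-4-yl or a longer chain carrying diethylamino would give a number nearer that of compound 1 or that of compound 4. Going by these compounds, it is also open whether the same amine swap would give a like step with 3,4-difluorophenyl on the carbonyl carbon.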